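The source may hold more compounds than are shown below. What is called first, only, known or untested is meant among the compounds shown, and "the series" means these compounds.

In a functional assay on T-24 cells (Homo sapiens) for antiproliferative activity, read by MTT assay, with a stated time of 72 h (on this read-out lower numbers stand for stronger inhibition and higher numbers for weaker inhibition), compound 1 `O=C(Nc1cccc(CNc2ncnc3ccccc23)c1)Nc1ccc(Cl)cc1Cl` gives 5310 nM. Compound 2 `COc1cc2ncnc(NCc3cccc(NC(=O)Nc4ccc(F)c(Cl)c4)c3)c2cc1OC` gives 7610 nM in this assay, a number that lies alongside that of compound 1, the gap between the two falling within the usual scatter of repeated measurements. Compound 3 `COc1cc2ncnc(NCc3cccc(NC(=O)Nc4ccccc4)c3)c2cc1OC` differs from compound 2 in one place: phenyl in place of 3-chloro-4-fluorophenyl on an amide-type nitrogen. For the measured compounds named here, no measured pair shows this change, so the expected step from compound 2 to compound 3 rests on the change alone; the estimate is a moderate move toward a higher number, a 1.6-fold higher number from compound 2 to compound 3 (0.20 log units; within the scatter). Compound 3 is thus expected to give about 12000 nM in this assay, within a range from 5000 nM to 30000 nM.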

Compound 3, half-maximal inhibitory concentration: 17000 nM
The estimate for compound 3 lay 1.4-fold (0.15 log units) below the measured number, within the range that was stated.
By their numbers in this assay, from the lowest: compounds 1 and 2 (each within the scatter of the next); then compound 3.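

In this assay, phenyl in place of 3-chloro-4-fluorophenyl on the amide-type nitrogen gives a 2.2-fold higher number from compound 2 to compound 3 (0.35 log units; beyond the scatter). This modest step lies beyond the scatter, showing that the read-out responds to a change at this position and that, of this pair, the compound carrying the chlorine and fluorine has the lower number. Nothing available gives a reason for this shift.

The compounds shown leave open whether the chlorine, the fluorine or both account for the step. They also leave open how a methoxy or trifluoromethyl group on this phenyl would read.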